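Swapping a dipeptide-like tail for a benzyl amide

The source may hold more compounds than are shown below. What is called first, only, known or untested is meant among the compounds shown, and "the series" means these compounds.

Measured compounds:
- Compound 1, `Cc1cc(C)cc(S(=O)(=O)c2c(C(=O)NCC(=O)NC(C)c3ccccc3)[nH]c3ccc(Cl)cc23)c1`, gives 29400 nM in an ADME assay on MT4 cells (Homo sapiens) for cytotoxicity, read by MTT assay; a lower number here means that less compound is tolerated, a higher number that more compound is tolerated.
- Compound 2, `Cc1cc(C)cc(S(=O)(=O)c2c(C(=O)NC(C)C(=O)NCc3ccco3)[nH]c3ccc(Cl)cc23)c1`, gives 24200 nM in this assay.

For the measured compounds named here, compound 2 holds the lowest of the two numbers in this assay, but its only neighbour is compound 1, and the step of a 1.2-fold lower number from compound 1 to compound 2 (0.08 log units; within the scatter) sits within the scatter, so the two compounds are indistinguishable on these data.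

Compound 3, `COc1cccc(F)c1CNC(=O)c1[nH]c2ccc(Cl)cc2c1S(=O)(=O)c1cc(C)cc(C)c1`, differs from compound 2 in one place: 2-fluoro-6-methoxybenzyl in place of 1-(((furan-2-yl)methyl)carbamoyl)ethyl on an amide-type nitrogen. Going by the values given here, the only measured step, from compound 1 to compound 2, also reshaped this same amide-type nitrogen substituent and left this assay essentially unchanged. Among the compounds with values here, the change into compound 3 is larger in kind, removing a second amide, yet there is no measured precedent for it here.

Compound 3 is therefore expected to show no step beyond the scatter, with a 1.0-fold higher number from compound 2 to compound 3 (0.01 log units; within the scatter) as the estimated step. The estimated value of compound 3 is 25000 nM, with a range from 10000 nM to 60000 nM.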

Compound 3, half-maximal cytotoxic concentration: > 49900 nM
Compound 3: a limit, no number (the forecaster's own chance of this, stated with the estimate: 15%); middle value at least 1.9-fold (0.30 log units) away from the limit.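

In this assay, the substituent on the amide-type nitrogen can shift the number after all, since 2-fluoro-6-methoxybenzyl in place of 1-(((furan-2-yl)methyl)carbamoyl)ethyl gives an at least 2.0-fold higher number from compound 2 to compound 3 (0.31 log units; beyond the scatter). The comparison with the other tail is less firm, showing an at least 1.6-fold higher number from compound 1 to compound 3 (0.22 log units; that floor lies within the scatter), so compound 3 cannot yet be separated from compound 1. The result for compound 3 is a limit of the assay and not a number: the limit of > 49900 nM in this assay, at which 1 of the 3 values shown sits.

The compounds shown leave open whether losing the carbamoyl group is enough for this shift or whether the fluoro and methoxy groups on the benzyl take part. A plain benzyl on the same nitrogen would separate these two readings, and a benzyl carrying a carboxylic acid would show how far this position tolerates a different kind of group.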